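The source may hold more compounds than are shown below. What is called first, only, known or untested is meant among the compounds shown, and "the series" means these compounds.

Measured in an assay for inhibition of RAC-alpha serine/threonine-protein kinase (Homo sapiens), read by HTRF, with a stated time of 1 h; on this read-out lower numbers stand for stronger inhibition and higher numbers for weaker inhibition:
compound 1 `COCC[C@@H]1C[C@@H](c2ccc(Cl)c(Cl)c2)[C@H](NC(=O)c2cc(-c3c(Cl)cnn3C)c(Cl)o2)CN1`, 7.01 nM
compound 2 `Cn1ncc(Cl)c1-c1cc(C(=O)N[C@@H]2CN[C@H](CCO)C[C@H]2c2ccc(Cl)c(Cl)c2)oc1Cl`, 2.74 nM
compound 3 `Cn1ncc(Cl)c1-c1cc(C(=O)N[C@@H]2CN[C@H](CC(O)CO)C[C@H]2c2ccc(Cl)c(Cl)c2)oc1Cl`, 3.79 nM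

Compound 3 sits second highest of the three numbers; its nearest neighbour is compound 2, at a 1.4-fold higher number from compound 2 to compound 3 (0.14 log units; within the scatter), and compound 1 lies furthest, at a 1.8-fold lower number from compound 1 to compound 3 (0.27 log units; within the scatter), both gaps within the scatter. Compound 4 `Cn1ncc(Cl)c1-c1cc(C(=O)N[C@@H]2CN[C@H](CCCO)C[C@H]2c2ccc(Cl)c(Cl)c2)oc1Cl` differs from compound 3 by hydrogen in place of hydroxy on a saturated chain carbon bound to two saturated chain carbons. For the measured compounds named here, the step that bears on it most is the one in which a hydroxymethyl entered on a saturated chain carbon, a 1.4-fold higher number from compound 2 to compound 3 (0.14 log units; within the scatter), which stayed within the scatter; the only step beyond it, a 2.6-fold lower number from compound 1 to compound 2 (0.41 log units; beyond the scatter), concerns an oxygen rather than a carbon. Taking away a hydroxy here is therefore expected to move this assay little, so for compound 4 the expected step is a 1.1-fold lower number from compound 3 to compound 4 (0.03 log units; within the scatter), giving an estimate of 3.5 nM with a range from 1.5 nM to 8 nM.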

Compound 4, half-maximal inhibitory concentration: 2.56 nM
Estimate against measurement, compound 4: 1.4-fold (0.14 log units) above; low and high end bracket the measured number.
By their numbers in this assay, from the lowest: compounds 4, 2, 3 and 1 (each within the scatter of the next, the first and the last beyond it).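

In this assay, the hydroxy on the saturated chain carbon bound to two saturated chain carbons proves dispensable, with a 1.5-fold lower number from compound 3 to compound 4 (0.17 log units; within the scatter), and the 3-hydroxypropyl chain reads like the shorter 2-hydroxyethyl chain, with a 1.1-fold lower number from compound 2 to compound 4 (0.03 log units; within the scatter). Against the methoxy-ended chain, the 3-hydroxypropyl chain gives a 2.7-fold lower number from compound 1 to compound 4 (0.44 log units; beyond the scatter), a modest gain that adds a second hydroxy-ended chain to the gap already seen in a 2.6-fold lower number from compound 1 to compound 2 (0.41 log units; beyond the scatter), though the 2,3-dihydroxypropyl chain goes against this pattern with a 1.8-fold lower number from compound 1 to compound 3 (0.27 log units; within the scatter).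

No available evidence explains why these chains read so alike. On these data alone, whether an amine, a carboxylic acid or a longer chain at this position would keep the number in this range remains open.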